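The compounds below may be only part of what the source reports. "The series", "measured", "known", "first", "only" and "open" are said of these compounds alone.

In an ADME assay on microsomes from liver (Mus musculus) for metabolic stability, read by mass spectrometry, with a stated time of 40 min, tested at 1 uM (a lower number here means that less of the compound is left, a higher number that more of the compound is left), compound 3 `COc1cc(N2CCC(C(=O)N3CCOCC3)CC2)ccc1Nc1nc(NC2CCCCC2)c2nc[nH]c2n1` gives 70%. Compound 2 `COc1cc(N2CCC(C(=O)N3CCC(N(C)C)C3)CC2)ccc1Nc1nc(NC2CCCCC2)c2nc[nH]c2n1` gives 60%, within the scatter of compound 3, while compound 1 `COc1cc(N2CCN(CC3CCOC3)CC2)ccc1Nc1nc(NC2CCCCC2)c2nc[nH]c2n1` gives 59%, lower than compound 3 by more than the scatter. Compound 4 `CCN(CC)CC1CCN(c2ccc(Nc3nc(NC4CCCCC4)c4nc[nH]c4n3)c(OC)c2)CC1` differs from compound 3 by one change, (diethylamino)methyl in place of (morpholin-4-yl)carbonyl on a saturated ring carbon. Going by the values given here, the only measured step that removes morpholin-4-yl is a number 10 percentage points higher from compound 2 to compound 3 (within the scatter), read here in reverse. It keeps the carbonyl, so it is only a loose guide. Among the compounds with values here, a small fall, no larger than that step and not clearly beyond the scatter, is expected in this assay. The estimated change is a number 10 percentage points lower from compound 3 to compound 4 (within the scatter). For compound 4 the estimate is 60%, with an expected range from 44% to 74%.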

Compound 4, percent of the compound remaining: 47%
Compound 4: middle estimate off by 13 percentage points, on the high side; the measured number falls inside the stated range.
By their numbers in this assay, from the lowest: compound 4; then compounds 1, 2 and 3 (each within the scatter of the next, the first and the last beyond it).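

In this assay, putting (diethylamino)methyl on the saturated ring carbon in place of either carbonyl group gives a drop beyond the scatter, with a number 23 percentage points lower from compound 3 to compound 4 (beyond the scatter) and a number 13 percentage points lower from compound 2 to compound 4 (beyond the scatter). Changing the whole group on the aromatic carbon to 4-((diethylamino)methyl)piperidin-1-yl also gives a number 12 percentage points lower from compound 1 to compound 4 (beyond the scatter). No measurement shown explains these falls. The compounds shown leave open whether the loss goes with the missing carbonyl or with the diethylamino group. A (morpholin-4-yl)methyl group on the same ring carbon would help separate the two.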